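Replacing naphthalen-2-yl with propyl: a small expected step

The source may report more compounds than this note shows. Statements on the series, on what has been measured and on what is new or still open speak of the compounds shown alone.

Compounds measured in a functional assay on A549 cells (Homo sapiens) for inhibition, read by MTT assay, with a stated time of 48 h; a lower number here means a stronger inhibitor, a higher number a weaker inhibitor
Compound 1 `Brc1ccc2[nH]cc(C(c3ccccc3)c3c[nH]c4ccc(Br)cc34)c2c1` gives 7500 nM
Compound 2 `Brc1ccc2[nH]cc(C(c3c[nH]c4ccc(Br)cc34)C3CCCCC3)c2c1` gives 5500 nM
Compound 3 `Brc1ccc2[nH]cc(C(c3ccc4ccccc4c3)c3c[nH]c4ccc(Br)cc34)c2c1` gives 8500 nM

Compound 3 cannot be separated from the other two on these numbers: a 1.1-fold higher number from compound 1 to compound 3 (0.05 log units; within the scatter) and a 1.5-fold higher number from compound 2 to compound 3 (0.19 log units; within the scatter) both lie within the scatter. The next compound, compound 4 `CCCC(c1c[nH]c2ccc(Br)cc12)c1c[nH]c2ccc(Br)cc12`, has propyl in place of naphthalen-2-yl on a saturated chain carbon bound to two aromatic carbons.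

All three measured steps bear on this change. They were made at the same place. The third, cyclohexyl in place of phenyl, gave a 1.4-fold lower number from compound 1 to compound 2 (0.13 log units; within the scatter) and also stayed within the scatter. In this assay no change at this carbon has yet given a step beyond the scatter, whether the group was aromatic or saturated. For the measured compounds named here, none of the measured compounds carries an open chain, however, so propyl goes beyond what has been tested and the range must stay wide. The estimate is a 1.2-fold lower number from compound 3 to compound 4 (0.08 log units; within the scatter) as an expected step that stays within the scatter. The estimated value for compound 4 is 7000 nM with an expected range (from 3500 nM to 14000 nM).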

Compound 4, half-maximal inhibitory concentration: 6500 nM
For compound 4 the middle estimate is 1.1-fold (0.03 log units) above the measured one; low and high end bracket the measured number.
By their numbers in this assay, from the lowest: compounds 2, 4, 1 and 3 (each within the scatter of the next).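

In this assay, propyl brings an open chain to this saturated chain carbon bound to two aromatic carbons, and it stays within the scatter of all three earlier groups: a 1.3-fold lower number from compound 3 to compound 4 (0.12 log units; within the scatter) for the exchange with naphthalen-2-yl, a 1.2-fold higher number from compound 2 to compound 4 (0.07 log units; within the scatter) for the exchange with cyclohexyl, and a 1.2-fold lower number from compound 1 to compound 4 (0.06 log units; within the scatter) for the exchange with phenyl. The earlier compounds shown here had only compared one ring system with another at this carbon, whereas compound 4 shows that a group with no ring at all cannot be told apart from them here. Among these four compounds, therefore, neither the presence of a ring nor the large difference in heavy atoms between naphthalen-2-yl and propyl separates one compound from another, and no compound goes against this.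

The compounds shown leave open whether an amine, a carboxylic acid or a longer chain at this carbon would give a step beyond the scatter, or whether the number depends instead on the bromine atoms of the shared core. No evidence is available to account for how little these numbers differ.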